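The source may report more compounds than this note shows. Statements on the series, on what has been measured and on what is new or still open speak of the compounds shown alone.

Compound 1 `CCCn1ncnc1-c1ccccc1NCC1=NCCN1` reaches 96% in a functional assay with Alpha-1A adrenergic receptor (Homo sapiens) as the target, read by calcium flux; on this read-out higher numbers stand for larger maximal responses and lower numbers for smaller maximal responses.
Compound 2 `CCn1cc(-c2ccccc2NCC2=NCCN2)cn1` reaches 0%.
Compound 3 `c1ccc(-c2cn[nH]c2)c(NCC2=NCCN2)c1` reaches 112%.

Among these three numbers compound 1 stands second highest: compound 3 lies above it beyond the scatter, and compound 2 lies far below it. Compound 4 `CCCCn1ncnc1-c1ccccc1NCC1=NCCN1` differs from compound 1 by methyl in place of hydrogen on a saturated chain carbon, three bonds along the chain from an aromatic nitrogen. Among the compounds with values here, the only measured step between compounds that differ in one place, a number 112 percentage points higher from compound 2 to compound 3 (beyond the scatter), concerns a group on an aromatic nitrogen of a different core, so it does not speak to lengthening a chain by one carbon. Within the data shown here, with no directly comparable step, the change is expected to stay within the scatter: a number 1 percentage points lower from compound 1 to compound 4 (within the scatter). Compound 4 is therefore estimated at 95%, with a range from 70% to 115%.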

Compound 4, largest response reached (reported as maximal response), in percent of the reference or control that the assay uses: 86%
Beside the measured number, compound 4's estimate is 9 percentage points above it; the measured number falls inside the stated range.
By their numbers in this assay, from the lowest: compound 2; then compounds 4 and 1 (each within the scatter of the next); then compound 3.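

In this assay the chain on the aromatic nitrogen goes from propyl to butyl with a number 10 percentage points lower from compound 1 to compound 4 (within the scatter) and so the maximal response holds when this position gains one carbon. Within the data shown here, this is the first step measured on the chain itself, and on the core of compound 1, where the earlier compounds offered no direct comparison. No measurement shown here explains this result. Going by these compounds, whether a longer chain such as hexyl, or an amine or a carboxylic acid carried on this chain, would keep the response stays open. So does the effect of shortening the chain to ethyl or methyl on this core.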